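From benzyloxy to anilino: compound 1 to compound 3

The compounds below may be only part of what the source reports. "The series", "measured", "known", "first", "only" and "open" are said of these compounds alone.

Compound 1 `C=C[C@@](C)(/C=C/c1ccc(OCc2ccccc2)cc1)CCC=C(C)C` has no exact number in a functional assay on HepG2 cells (Homo sapiens) for cytotoxicity, with a stated time of 72 h (a higher number here means that more compound is needed for the effect, a lower number that less compound is needed), because compound 1 gives > 52000 nM as a limit of the assay. Compound 2 `COc1ccc(/C=C/[C@@](C)(/C=C/c2ccc(O)c(C=O)c2)CCC=C(C)C)cc1` likewise gives > 26000 nM as a limit. Compound 3 `C=C[C@@](C)(/C=C/c1ccc(Nc2ccccc2)cc1)CCC=C(C)C` differs from compound 1 in one place, with anilino in place of benzyloxy on an aromatic carbon para to a large group. Within the data shown here, no measured step is available as a guide. The expected change in this assay is an at least 1.3-fold lower number from compound 1 to compound 3 (0.11 log units; that floor lies within the scatter) and is estimated to stay within the usual scatter, in neither direction. Compound 3 is estimated at 40000 nM (expected range 15000 nM to 100000 nM).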

Compound 3, half-maximal effective concentration: > 52000 nM
Compound 3 was reported as a limit; the forecaster's own chance of this, stated with the estimate: 65%; at least 1.3-fold (0.11 log units) between middle value and limit.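

In this assay, among these compounds, compound 3 gives > 52000 nM, a limit of the assay, as compound 1 also does, and no step from compound 1 to compound 3 can be read. The compounds shown leave open whether anilino and benzyloxy differ at all in this read-out.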